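This account rests on a few compounds, and the source may have more. Where it says the series, first, only, none or still open, it means among the compounds named here.

The two compounds below have been measured in a functional assay on SK-N-SH cells (Homo sapiens) for cytotoxicity, read by MTT assay, with a stated time of 48 h (on this read-out lower numbers stand for stronger inhibition and higher numbers for weaker inhibition), so far.

- Compound 1 `COc1ccc(/C=C/c2cc(OC)c(OC)c(OC)c2-c2ccccc2)cc1` gives 11000 nM in this test
- Compound 2 `COc1cc(/C=C/c2ccccc2)c(-c2ccccc2)c(OC)c1OC` gives 63000 nM in this test

Of these two numbers, compound 2 (63000 nM) holds the higher one, so it is the weaker of the pair. Compound 3 `COc1cc(/C=C/c2ccc(C)cc2)c(-c2ccccc2)c(OC)c1OC` is still unmeasured. It is compound 2 with one change (methyl in place of hydrogen on an aromatic carbon), methyl in place of hydrogen on an aromatic carbon, para to a large group.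

Within the data shown here, only one measured step bears on this. Hydrogen in place of methoxy at that same place gave a modest rise (a 5.7-fold higher number from compound 1 to compound 2 (0.76 log units; beyond the scatter)). Read backwards, a group at this place went with the lower number, but one pair sets no rule, and a methyl is not a methoxy. A drop in the same direction is therefore expected, though smaller and close to the edge of the scatter. The expected step is a 2.1-fold lower number from compound 2 to compound 3 (0.32 log units; beyond the scatter) on this estimate. Compound 3 is estimated at 30000 nM with an expected range from 11000 nM to 70000 nM in this read-out.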

Compound 3, half-maximal inhibitory concentration: 31000 nM
Estimate against measurement, compound 3: 1.0-fold (0.01 log units) below; low and high end bracket the measured number.
By their numbers in this assay, from the lowest: compound 1; then compound 3; then compound 2.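

In this assay there is a 2.0-fold lower number from compound 2 to compound 3 (0.31 log units; beyond the scatter) once a methyl group is added, so the fall in number at this place does not depend on having a methoxy group there, since a plain carbon group, with no hydrogen-bond acceptors, also goes with it. The new compound also allows methyl and methoxy to be compared directly at the same place, and the change from methoxy to methyl gives a 2.8-fold higher number from compound 1 to compound 3 (0.45 log units; beyond the scatter) even though the methyl still keeps part of the gain over hydrogen. Across these three compounds the numbers therefore rise in the order methoxy, methyl, hydrogen, with every step beyond the scatter, but nothing available explains that order.

Three groups cannot show whether this order extends to others at this place, such as a hydroxyl, an amine, a carboxylic acid or a longer chain like butyl. As far as these compounds go, it also remains open whether methyl or methoxy would have a similar effect on another carbon of this ring, or on the phenyl ring that all three compounds share.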